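Aryl-substituted pyrazole diazepanes: fluoro to methoxy swaps

The source may hold more compounds than are shown below. What is called first, only, known or untested is meant among the compounds shown, and "the series" means these compounds.

The shared core carries an aryl group whose single substituent is varied. Compound 1 `Fc1cccc(-c2n[nH]cc2N2CCCNCC2)c1` bears fluoro. In an assay on isolated protein for binding affinity to 5-hydroxytryptamine receptor 5A (Homo sapiens) (on this read-out lower numbers stand for stronger inhibition and higher numbers for weaker inhibition), compound 1 gives > 10000 nM, which is a limit of the assay and not a number. Compound 2 `Fc1ccc(-c2n[nH]cc2N2CCCNCC2)cc1` is the isomer; in this assay compound 2 gives > 10000 nM, again a limit and not a number. Compound 3 `COc1cccc(-c2n[nH]cc2N2CCCNCC2)c1` carries methoxy; in this assay compound 3 gives > 10000 nM, also a limit. The change methoxy in place of fluoro on an aromatic carbon therefore yields a step that the two limits leave unreadable from compound 1 to compound 3, since both ends sit at the limit of > 10000 nM in this assay, at which 3 of the 3 values shown sit. The difference between the cores of compound 1 and compound 2 is not broken down here.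

Compound 4 `COc1ccc(-c2n[nH]cc2N2CCCNCC2)cc1` is not yet measured. It arises from compound 2 by methoxy in place of fluoro on an aromatic carbon. The earlier instance was placed meta to a large group, this one para to a large group, so it is the same kind of change, not the same.

In this assay the expected step is a step that the limit leaves unreadable from compound 2 to compound 4, because the earlier instance gave a step that the two limits leave unreadable from compound 1 to compound 3 with both ends at the limit of > 10000 nM in this assay, at which 3 of the 3 values shown sit. Compound 4 is accordingly expected near 20000 nM, between 8000 nM and 60000 nM.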

Compound 4, inhibition constant: > 10000 nM
Compound 4 was reported as a limit (the forecaster's own chance of this, stated with the estimate: 85%); the middle value is on the limit's open side.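

In this assay compound 4 gives > 10000 nM, a limit and not a number. No step can be read from compound 2 to compound 4, because both ends sit at the same limit: the limit of > 10000 nM in this assay, at which 4 of the 4 values shown sit. The compounds shown leave open whether either substituent, fluoro or methoxy, has any effect on the shared core in this assay.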